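Pyrazolyl urea series: methyl on the pendant phenyl

A few compounds are considered here, and "the series" means these few. Any claim that something is new, unique, unknown or untested is made for them only; others in the source may bear on it.

Measured so far:
compound 1 `CC(C)(C)c1cc(NC(=O)Nc2cc(C(F)(F)F)cc(C(F)(F)F)c2)n(-c2ccccc2)n1`: -0.5 degrees C
compound 2 `COc1cccc(NC(=O)Nc2cc(C(C)(C)C)nn2-c2ccccc2)c1`: 3.7 degrees C

Both compounds were run in an assay on isolated protein for inhibition of serine/threonine-protein kinase 10 (Homo sapiens), read by thermal shift assay, tested at 10 uM; on this read-out higher numbers stand for stronger stabilisation of the target against heat and lower numbers for weaker stabilisation of the target. Compound 1 gives -0.5 degrees C, the lower of the two numbers. For the measured compounds named here, compound 2 gives 3.7 degrees C, which stands higher than compound 1 by more than the scatter; no single-point step between compound 1 and compound 2 is defined, so only these two values can be set side by side.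

Compound 3 `Cc1ccc(-n2nc(C(C)(C)C)cc2NC(=O)Nc2cc(C(F)(F)F)cc(C(F)(F)F)c2)cc1` is not yet measured. It differs from compound 1 by methyl in place of hydrogen on an aromatic carbon, a methyl in place of hydrogen on an aromatic carbon. Going by the values given here, nothing among the measured compounds shows what this change does in this assay, so no direction can be read from the data. The expected step from compound 1 to compound 3 is therefore a number 0.50 degrees C higher from compound 1 to compound 3 (within the scatter), not beyond the scatter in either direction. Compound 3 is estimated at 0 degrees C, with a range from -1.5 degrees C to 1.5 degrees C.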

Compound 3, shift of the target's melting temperature: -0.5 degrees C
For compound 3 the middle estimate is 0.50 degrees C above the measured one, and the stated range covers the measured number.
By their numbers in this assay, from the lowest: compounds 1 and 3 (each within the scatter of the next); then compound 2.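

Taking phenyl to 4-methylphenyl on the core of compound 1 gives, in this assay, no change at the digits printed from compound 1 to compound 3 (within the scatter). For the compounds shown here, this is the first reading of any substituent on this ring, and it shows that a methyl on this aromatic carbon, para to a large group, leaves the read-out within the scatter. The starting point, compound 1, stands at -0.5 degrees C. The compounds shown offer no measurement that would explain this flat step.

From the compounds shown here alone, because one step from a compound with so low a number says little about other starting points (here no cause is claimed), it remains open whether the same methyl would read the same on the core of compound 2, which stands at 3.7 degrees C. Also open is what a different group at this carbon would do, such as a hydroxyl, an aminomethyl or a carboxylic acid, or a longer chain such as propyl.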